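Chain extension of the hydroxamate linker in the shared core

The source may report more compounds than this note shows. Statements on the series, on what has been measured and on what is new or still open speak of the compounds shown alone.

Among the measured compounds shown here, in an assay on isolated protein for inhibition of histone deacetylase 8 (Homo sapiens), read by fluorescence, with a stated time of 1 h (on this read-out lower numbers stand for stronger inhibition and higher numbers for weaker inhibition), compound 2 `COc1ccc(N(C)c2nc(C)nc3ccccc23)cc1OCCCCC(=O)NO` gives 5190 nM as the only number available for the series. Compound 1 `COc1ccc(N(C)c2nc(C)nc3ccccc23)cc1OCC(=O)NO` is reported only as a limit in this assay and shows > 1000 nM there. The step that the limit leaves unreadable from compound 1 to compound 2 cannot be sized because the limit of > 1000 nM in this assay, at which 1 of the 2 values shown sits, masks its starting point. Compound 3 `COc1ccc(N(C)c2nc(C)nc3ccccc23)cc1OCCCCCC(=O)NO` is not yet measured and differs from compound 2 by (hydroxycarbamoyl)methyl in place of hydroxycarbamoyl on a saturated chain carbon, four bonds along the chain from an oxygen on an aromatic ring. No readable measured step bears on this change, so no direction follows from the data. The expected step of a 1.2-fold lower number from compound 2 to compound 3 (0.06 log units; within the scatter) is within the scatter. Compound 3 is estimated at 4500 nM with a range of 1500 nM to 13000 nM in this assay.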

Compound 3, half-maximal inhibitory concentration: 1530 nM
For compound 3 the middle estimate is 2.9-fold (0.47 log units) above the measured one; low and high end bracket the measured number.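

In this assay, among the compounds shown here, the chain extension gives the first readable step: a 3.4-fold lower number from compound 2 to compound 3 (0.53 log units; beyond the scatter). This position therefore responds to a single added chain carbon, which compound 1 and compound 2 alone could not show. Compound 1 is reported only as a limit, so neither step from it can be read: the limit of > 1000 nM in this assay, at which 1 of the 3 values shown sits.

On these data alone, whether a longer chain would extend this step or reverse it remains open, as one readable step sets no trend. Also open, as far as these compounds go, is how a carboxylic acid in place of the hydroxycarbamoyl end would compare with compound 3.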